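Compound 4: Trifluoromethyl in Place of Methyl

A few compounds are considered here, and "the series" means these few. Any claim that something is new, unique, unknown or untested is made for them only; others in the source may bear on it.

Values in a functional assay on HCT-116 cells (Homo sapiens) for cytotoxicity, read by MTT assay, with a stated time of 48 h; on this read-out higher numbers stand for weaker inhibition of growth and lower numbers for stronger inhibition of growth:
- compound 1 `Cn1c(C(F)(F)F)nc2cc(Cl)c(Cl)cc21`: 56000 nM
- compound 2 `Clc1cc2ncn(C3CCCC3)c2cc1Cl`: 37000 nM
- compound 3 `Cc1nc2cc(Cl)c(Cl)cc2n1C1CCCC1`: 13000 nM

Of these three, compound 3 has the lowest number, 13000 nM. Compound 4 `FC(F)(F)c1nc2cc(Cl)c(Cl)cc2n1C1CCCC1` has trifluoromethyl in place of methyl on an aromatic carbon. One measured step involves this carbon: methyl in place of hydrogen gave a 2.8-fold lower number from compound 2 to compound 3 (0.45 log units; beyond the scatter), a modest change. Compound 1 also carries trifluoromethyl, but it differs from compound 4 elsewhere. Compound 1 gives 56000 nM. Going by the values given here, no measured step shows this exact swap, so only a small shift in this assay is expected, perhaps slightly lower and probably not beyond the scatter. The expected step is a 1.3-fold lower number from compound 3 to compound 4 (0.11 log units; within the scatter). For compound 4 the estimated value is 10000 nM, with an expected range of 4000 nM to 30000 nM.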

Compound 4, concentration for 50% growth inhibition: 22000 nM
Estimate against measurement, compound 4: 2.2-fold (0.34 log units) below, and the stated range covers the measured number.
By their numbers in this assay, from the lowest: compounds 3, 4, 2 and 1 (each within the scatter of the next, the first and the last beyond it).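

In this assay trifluoromethyl in place of methyl on this aromatic carbon gives a 1.7-fold higher number from compound 3 to compound 4 (0.23 log units; within the scatter) and trifluoromethyl in place of hydrogen gives a 1.7-fold lower number from compound 2 to compound 4 (0.23 log units; within the scatter) so compound 4 cannot be told apart from either neighbour, even though those two neighbours differ beyond the scatter. Going by these compounds alone, on the aromatic nitrogen, with trifluoromethyl kept, cyclopentyl in place of methyl gives a 2.5-fold lower number from compound 1 to compound 4 (0.41 log units; beyond the scatter) and this is the only new step beyond the scatter. No available evidence explains these steps.

Going by these compounds, what an amine or a longer chain would do on this aromatic carbon stays open. So does the effect of a phenyl ring on the aromatic nitrogen.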